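Removing a Methoxy Group from a Shared Core

The source may report more compounds than this note shows. Statements on the series, on what has been measured and on what is new or still open speak of the compounds shown alone.

Three compounds were measured in a functional assay on A549 cells (Homo sapiens) for antiproliferative activity, read by sulforhodamine B assay, with a stated time of 48 h; a lower number here means a stronger inhibitor, a higher number a weaker inhibitor:

compound 1, `COc1cc(OC)c2sc(-c3ccc(N/C=C\C(=O)c4ccc(OC)c(O)c4)c(C)c3)nc2c1`, gives 14300 nM;
compound 2, `COc1ccc(C(=O)/C=C\Nc2ccc(-c3nc4cc(OC)c(OC)c(OC)c4s3)cc2C)cc1O`, gives 15400 nM;
compound 3, `COc1cc(C(=O)/C=C\Nc2ccc(-c3nc4cc(OC)c(OC)c(OC)c4s3)cc2)cc([N+](=O)[O-])c1OC`, gives 11800 nM.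

Compound 1 and compound 2 differ in one place, (hydrogen in place of methoxy on an aromatic carbon), and in this assay that change made a 1.1-fold lower number from compound 2 to compound 1 (0.03 log units; within the scatter). The difference between the core of compound 3 and that of compound 2 is not broken down here; the value of compound 3 stands within the scatter of both compound 1 and compound 2.

Compound 4, `COc1cc(OC)c2sc(-c3ccc(N/C=C\C(=O)c4cc(OC)c(OC)c([N+](=O)[O-])c4)cc3)nc2c1`, is not yet measured. Compound 3 to compound 4 is the same change, (hydrogen in place of methoxy on an aromatic carbon), with the same surroundings at the place. Because a 1.1-fold lower number from compound 2 to compound 1 (0.03 log units; within the scatter) lay within the scatter, the step of a 1.1-fold lower number from compound 3 to compound 4 (0.03 log units; within the scatter) is expected to be small as well. Compound 4 is therefore estimated at 11000 nM, with a likely range of 5000 nM to 25000 nM.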

Compound 4, half-maximal inhibitory concentration: 13000 nM
The estimate for compound 4 lay 1.2-fold (0.07 log units) below the measured number, within the range that was stated.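

In this assay, putting hydrogen in place of methoxy on the core of compound 3 gave a 1.1-fold higher number from compound 3 to compound 4 (0.04 log units; within the scatter). Set beside the earlier step on the other core, the two agree: the same change on two cores in this assay, a 1.1-fold lower number (0.03 log units; within the scatter) from compound 2 to compound 1 and a 1.1-fold higher number (0.04 log units; within the scatter) from compound 3 to compound 4, 1.2-fold (0.07 log units) apart, within the scatter of two such steps. Within the data shown here, this shows that the change carried over between these two cores with no readable effect on the number, but it rests on only two pairs and does not show that the same would hold on any other core or in any other assay.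

The compounds shown carry only methoxy or hydrogen at this place. As far as these compounds go, whether an amine or a longer alkoxy chain there would give a step beyond the scatter remains open.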